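This account rests on a few compounds, and the source may have more. Where it says the series, first, only, none or still open, it means among the compounds named here.

Of the compounds shown here, two have been measured in an ADME assay on MT4 cells (Homo sapiens) for cytotoxicity, read by MTT assay; on this read-out lower numbers stand for higher toxicity in this test and higher numbers for lower toxicity in this test. Compound 1 `O=C(CSc1nncnc1-c1cccc2ccccc12)Nc1ccc([N+](=O)[O-])cc1Cl` gives 150000 nM in this assay, the higher of the two numbers on hand. Compound 2 `O=C(CSc1nncnc1-c1ccccc1Cl)Nc1ccccc1[N+](=O)[O-]` gives 63000 nM in this assay, a lower number, and the gap between compound 1 and compound 2 lies beyond the usual scatter; the two differ in more than one place, so only their values are noted here, not a step. Compound 3 `O=C(CSc1nncnc1-c1cccc2ccccc12)Nc1ccc(Cl)cc1Cl` has not yet been measured in this assay. Set against compound 1 it shows (chloro in place of nitro on an aromatic carbon), with the shared core otherwise kept. Among the measured compounds shown here, no measured pair bears on this change. The step in this assay is expected to be a 1.3-fold lower number from compound 1 to compound 3 (0.10 log units; within the scatter), meaning no shift beyond the scatter. The value of compound 3 in this assay is accordingly estimated at 120000 nM, within a range from 40000 nM to 300000 nM.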

Compound 3, half-maximal cytotoxic concentration: 254000 nM
Compound 3: middle estimate off by 2.1-fold (0.33 log units), on the low side; low and high end bracket the measured number.
By their numbers in this assay, from the lowest: compound 2; then compounds 1 and 3 (each within the scatter of the next).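

In this assay, chloro in place of nitro on this aromatic carbon, para to a large group and meta to a chloro group, gives a 1.7-fold higher number from compound 1 to compound 3 (0.23 log units; within the scatter). Among the compounds shown here, this is the first pair that differs in one place, and it shows that exchanging 2-chloro-4-nitrophenyl for 2,4-dichlorophenyl, with the loss of the nitro group's 3 heavy atoms for the single chlorine, leaves the read-out within the usual scatter on the core of compound 1. Nothing on hand explains why the read-out holds across this change.

From the compounds shown here alone, it remains open whether an amine, a methoxy group or a carboxylic acid on the same carbon would also stay within the scatter. This single pair also cannot say whether the exchange reads the same when the other chloro group is absent.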